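Methoxy for trifluoromethyl on the fused core, cytotoxicity

The compounds below may be only part of what the source reports. "The series", "measured", "known", "first", "only" and "open" are said of these compounds alone.

In an ADME assay on THP-1 cells (Homo sapiens) for cytotoxicity (a lower number here means that less compound is tolerated, a higher number that more compound is tolerated), compound 2 `Fc1ccc(Nc2c(-c3ccccn3)nc3cc(C(F)(F)F)ccn23)cc1` gives 23700 nM, the highest of the two numbers in hand. Among the measured compounds shown here, compound 1 `COc1ccn2c(Nc3cc(F)cc(F)c3)c(-c3ccccn3)nc2c1` gives 4300 nM; it differs from compound 2 in more than one place, so the two values show only that compound 1 sits well below compound 2. Compound 3 `COc1ccn2c(Nc3ccc(F)cc3)c(-c3ccccn3)nc2c1` carries methoxy in place of trifluoromethyl on an aromatic carbon. For the measured compounds named here, no measured pair isolates this change. Compound 1 also carries the entering methoxy and gives 4300 nM. On that basis a step down from compound 2 to compound 3 is expected, a 2.6-fold lower number from compound 2 to compound 3 (0.42 log units; beyond the scatter), its size uncertain. Compound 3 is estimated at 9000 nM, within 3000 nM to 27000 nM.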

Compound 3, half-maximal cytotoxic concentration: 4560 nM
Compound 3: middle estimate off by 2.0-fold (0.30 log units), on the high side; the range from low to high includes it.
By their numbers in this assay, from the lowest: compounds 1 and 3 (each within the scatter of the next); then compound 2.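

Methoxy in place of trifluoromethyl on an aromatic carbon, opposite the ring nitrogen, now has a single-change reading in this assay: a 5.2-fold lower number from compound 2 to compound 3 (0.72 log units; beyond the scatter), so a change at this position alone moves the number beyond the scatter. Swapping the aryl group on the nitrogen, 4-fluorophenyl in place of 3,5-difluorophenyl, gives a 1.1-fold higher number from compound 1 to compound 3 (0.03 log units; within the scatter), so with methoxy on the core this swap does not separate compound 1 and compound 3. Nothing measured here offers an explanation for either step. On these data alone, whether the methoxy step holds with 3,5-difluorophenyl on the nitrogen remains open, as does where a nitrile, an amine or a carboxylic acid at this position would fall.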